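Flipping One Double Bond: What to Expect for Compound 3

The source may hold more compounds than are shown below. What is called first, only, known or untested is meant among the compounds shown, and "the series" means these compounds.

Compound 1 `COc1ccc(/C=C/C(=O)OC[C@H]2O[C@@H](O[C@@H]3OC=C[C@@]4(O)[C@H](O)C[C@](C)(O)[C@@H]34)[C@H](O)[C@@H](O)[C@@H]2O)cc1`: 60.3%
Compound 2 `COc1ccc(/C=C\C(=O)O[C@@]2(C)C[C@@H](O)[C@]3(O)C=CO[C@@H](O[C@@H]4O[C@H](CO)[C@@H](O)[C@H](O)[C@H]4O)[C@@H]32)cc1`: 49.6%

In a functional assay (Cortical neurone cells, Rattus norvegicus, strain Sprague-Dawley), read by spectrophotometry and LDH release, with stated times of 1 h and 24 h, tested at 10 uM (a lower number here means a weaker effect, a higher number a stronger effect of the compound at the concentration tested), compound 1 gives 60.3%, the higher of the two numbers, while compound 2 gives 49.6%, a gap beyond the usual scatter. Compound 3 `COc1ccc(/C=C\C(=O)OC[C@H]2O[C@@H](O[C@@H]3OC=C[C@@]4(O)[C@H](O)C[C@](C)(O)[C@@H]34)[C@H](O)[C@@H](O)[C@@H]2O)cc1` has not yet been measured. It differs from compound 1 only in this respect: the two compounds have the same atoms and bonds and differ only in configuration as drawn: 1 of 11 stereo elements differ; a double bond is drawn E in compound 1 and Z in compound 3. Going by the values given here, no measured pair isolates this single change, and compound 2, which also carries the Z form, is not a one-change partner of either compound. A small downward step, likely within the scatter, is therefore expected. The expected step is a number 6.3 percentage points lower from compound 1 to compound 3 (within the scatter). Compound 3 is estimated at 54%, with a range from 40% to 68%.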

Compound 3, a percentage reported as activity, at one concentration (the size of the read-out at that concentration, not a potency): 46.6%
Beside the measured number, compound 3's estimate is 7.4 percentage points above it, and the stated range covers the measured number.
By their numbers in this assay, from the lowest: compounds 3 and 2 (each within the scatter of the next); then compound 1.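

Going by these compounds alone, this is the first pair that isolates the geometry of the double bond: in this assay, going from the E form to the Z form gives a number 13.7 percentage points lower from compound 1 to compound 3 (beyond the scatter). The step can be assigned to that double bond alone because of one structural fact: the fact that compounds 1 and 3 differ only in the configuration as drawn. At this position, then, geometry alone is enough to shift the read-out, with every atom and bond unchanged.

On these data alone, whether the gap holds at other concentrations stays open. Also open, as far as these compounds go, is whether it would survive an amine or a carboxylic acid in place of the methoxy group.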